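The compounds below may be only part of what the source reports. "The series", "measured", "known", "first", "only" and "open" are said of these compounds alone.

The series shares one core, seen first in compound 1 `Cc1c(C(=O)N/N=C\c2c(O)cccc2F)oc2cccc(O)c12`, in which a functional assay on PC-3 cells (Homo sapiens) for inhibition (on this read-out lower numbers stand for stronger inhibition and higher numbers for weaker inhibition), gives compound 1 a value of 8050 nM. Compound 2 `COc1ccccc1/C=N\NC(=O)c1oc2cccc(O)c2c1C` carries a 2-methoxyphenyl on the carbon with a double bond to nitrogen, and in this assay compound 2 gives 32700 nM. For the measured compounds named here, of the two numbers, compound 2 stands highest: the step of a 4.1-fold higher number from compound 1 to compound 2 (0.61 log units; beyond the scatter) is the only measured step, and it exchanges the 2-fluoro-6-hydroxyphenyl of compound 1 for the 2-methoxyphenyl of compound 2.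

Compound 3 `COc1cccc(/C=N\NC(=O)c2oc3cccc(O)c3c2C)c1` differs from compound 2 as follows: 3-methoxyphenyl in place of 2-methoxyphenyl on a carbon with a double bond to nitrogen. Going by the values given here, no measured step concerns moving the methoxy group from the 2-position to the 3-position of the phenyl; the step from compound 1 to compound 2 changed which groups sit on the phenyl, not where a single methoxy stands, so it bears on this question only loosely, as a sign that this phenyl is sensitive to change at all. With nothing more to go on, a step within the usual scatter in this assay is expected for compound 3, in either direction. For compound 3 the estimate in this assay is 30000 nM, within 9000 nM and 100000 nM, which corresponds to an expected step of a 1.1-fold lower number from compound 2 to compound 3 (0.04 log units; within the scatter).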

Compound 3, half-maximal inhibitory concentration: >= 40000 nM
Compound 3: a limit, no number (the forecaster's own chance of this, stated with the estimate: 25%); middle value at least 1.3-fold (0.12 log units) away from the limit.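

Compound 3 gives >= 40000 nM in this assay as a limit and not a number: the limit of >= 40000 nM in this assay, at which 1 of the 3 values shown sits. Moving the methoxy from the 2-methoxyphenyl to the 3-methoxyphenyl gives an at least 1.2-fold higher number from compound 2 to compound 3 (0.08 log units; that floor lies within the scatter) and this floor does not separate the two placements, though it shows that the shift on the phenyl does not bring the number down. Set against the 2-fluoro-6-hydroxyphenyl, the 3-methoxyphenyl gives an at least 4.9-fold higher number from compound 1 to compound 3 (0.69 log units; beyond the scatter) and so a second methoxyphenyl on the carbon with a double bond to nitrogen now stands on the weaker side of that group, beyond the scatter, which means the loss seen earlier is not confined to the 2-methoxyphenyl.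

Going by these compounds, how far compound 3 truly lies past its limit stays open, and with it whether the placement of the methoxy matters at all. Also open, on these data alone, is whether a 2-hydroxyphenyl or a 2-fluorophenyl alone would keep the lower number of compound 1, and how an amine or a carboxylic acid on this phenyl would read.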